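The source may report more compounds than this note shows. Statements on the series, on what has been measured and on what is new or still open speak of the compounds shown alone.

Measured so far:
compound 1 `CCCc1ccc(OCC(=O)N(CC)Cc2cccs2)cc1`, 1810 nM
compound 2 `CCN(Cc1cccs1)C(=O)COc1ccc(C)cc1O`, 8 nM

In an assay on HEK293 cells for agonist activity at transient receptor potential cation channel subfamily M member 8 (Homo sapiens), read by fluorescence and calcium flux, with a stated time of 15 min (a higher number here means that more compound is needed for the effect, a lower number that less compound is needed), compound 1 gives the higher of the two numbers; compound 2 gives 8 nM, a gap well beyond the scatter, but the two differ in more than one place, so no single step can be read from that pair.

Compound 3 `CCN(Cc1cccs1)C(=O)COc1ccc(C#N)cc1` differs from compound 1 by cyano in place of propyl on an aromatic carbon. Among the compounds with values here, nothing among the measured compounds shows what this exchange does. The step from compound 1 to compound 3 in this assay is estimated at a 1.4-fold higher number from compound 1 to compound 3 (0.14 log units; within the scatter), no larger than the scatter, in no settled direction. Compound 3 is expected near 2500 nM, within 500 nM to 12000 nM.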

Compound 3, half-maximal effective concentration: 1990 nM
Beside the measured number, compound 3's estimate is 1.3-fold (0.10 log units) above it; low and high end bracket the measured number.
By their numbers in this assay, from the lowest: compound 2; then compounds 1 and 3 (each within the scatter of the next).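

In this assay, cyano in place of propyl on the aromatic carbon para to a large group gives a 1.1-fold higher number from compound 1 to compound 3 (0.04 log units; within the scatter), so this one exchange does not separate the two compounds. At this position, a hydrogen-bond acceptor entering and one heavy atom fewer leave the number within the scatter. No measured evidence bears on this result.

On these data alone, whether an amine, a carboxylic acid or a longer chain on this aromatic carbon would behave the same stays open. Also open, as far as these compounds go, is which of its differences goes with the 8 nM of compound 2.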